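Chloro to Fluoro on a Shared Acid Core

A few compounds are considered here, and "the series" means these few. Any claim that something is new, unique, unknown or untested is made for them only; others in the source may bear on it.

Three compounds share one core, seen in compound 1 `COc1ccc(-c2cccc(COc3ccc([C@H](CC(=O)O)c4nccn4C)cc3)c2)cc1`, compound 2 `Cc1cc(Cl)ccc1-c1cc(COc2ccc([C@H](CC(=O)O)c3nccn3C)cc2)ccc1C` and compound 3 `Cc1cc(Cl)ccc1-c1cccc(COc2ccc([C@H](CC(=O)O)c3nccn3C)cc2)c1`. In an assay on CHO cells for agonist activity at Free fatty acid receptor 1 (Homo sapiens), read by luminescence, with a stated time of 20 s, in the presence of a further agent that is not named here (on this read-out lower numbers stand for an effect already at smaller amounts and higher numbers for an effect only at larger amounts of compound), compound 1 has "not determined" (no result reported). In this assay compound 2 gives 9800 nM, and compound 3 gives 10000 nM. Compound 3 holds the highest of the two numbers, yet the step of a 1.0-fold higher number from compound 2 to compound 3 (0.01 log units; within the scatter) lies within the scatter, so the two cannot be told apart on these data.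

The unmeasured compound 4 `Cc1cc(F)ccc1-c1cccc(COc2ccc([C@H](CC(=O)O)c3nccn3C)cc2)c1` differs from compound 3 in one place: fluoro in place of chloro on an aromatic carbon. Among the measured compounds shown here, no measured step involves such an exchange of chloro for fluoro; the only measured step, a 1.0-fold higher number from compound 2 to compound 3 (0.01 log units; within the scatter), concerns a different change and is itself within the scatter. For compound 4 in this assay, therefore, no step beyond the scatter is expected. The step expected for compound 4 is no change at the digits printed from compound 3 to compound 4 (within the scatter). Compound 4 is estimated at 10000 nM, with a range from 4000 nM to 25000 nM.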

Compound 4, half-maximal effective concentration: 21000 nM
Compound 4: middle estimate off by 2.1-fold (0.32 log units), on the low side; measured number inside the range.
By their numbers in this assay, from the lowest: compounds 2 and 3 (each within the scatter of the next); then compound 4.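

In this assay, among the compounds shown here, the exchange of chloro for fluoro, which turns the 4-chloro-2-methylphenyl group into the 4-fluoro-2-methylphenyl group, gives a 2.1-fold higher number from compound 3 to compound 4 (0.32 log units; beyond the scatter) and is the first step in this set to clear the scatter, though only modestly. For the compounds shown here, the only earlier step of a 1.0-fold higher number from compound 2 to compound 3 (0.01 log units; within the scatter) replaced a methyl with hydrogen at another place and could not be told from noise, so this position is the first place where a single change shows up in the numbers. Nothing measured here gives a reason for the shift.

The compounds shown leave open how a bromine, a nitrile or an amine at this position would read. They also leave open whether the gap between chloro and fluoro would persist with the extra methyl of compound 2 in place.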